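Side Chain Swap: Guanidine Out, Carboxy In

This account rests on a few compounds, and the source may have more. Where it says the series, first, only, none or still open, it means among the compounds named here.

Compound 2 `N=C(N)NCCC[C@H](NC(=O)CN(c1nc(Cl)nc2[nH]cnc12)C1CC1)C(=O)O` is tested in a functional assay on the whole organism (Tail, strain ICR) with Mus musculus as the target, in the tail flick test, with a stated time of 90 min, at a dose of 25 umol/kg by the oral route (a higher number here means a stronger effect of the compound at the dose given, a lower number a weaker effect), where compound 2 gives 27.6%. Its nearest neighbour, compound 3 `N=C(N)NCCC[C@H](NC(=O)CN(c1nc(Cl)nc2[nH]cnc12)C1CC1)C(=O)OCc1ccccc1`, gives 30.4% in this assay, and compound 1 `NC(=O)CC[C@H](NC(=O)CN(c1ncnc2c1ncn2C1CCCCO1)C1CC1)C(=O)OCc1ccccc1` gives 37.8%. Compound 2 thus holds the lowest of the three numbers: the gap to compound 3 is within the scatter, while the gap to compound 1 lies beyond it. Among the measured compounds shown here, only one step between measured compounds exists, a number 2.8 percentage points higher from compound 2 to compound 3 (within the scatter), and it concerns the oxygen next to the carbonyl group, not the side chain. Compound 4 `O=C(O)CC[C@H](NC(=O)CN(c1nc(Cl)nc2[nH]cnc12)C1CC1)C(=O)O` arises from compound 2 by a group of 3 heavy atoms (1 carbon, 2 oxygen; no ring) in place of a group of 5 heavy atoms (2 carbon, 3 nitrogen; no ring), on a saturated chain carbon, three bonds along the chain from an amide-type nitrogen and a carbonyl carbon. For the measured compounds named here, no measured pair alters this part of the molecule, so the guidance is indirect: the one step that does exist stays within the scatter, and compound 1, with another side chain and another core, differs from compound 2 by an amount only just beyond it. The expectation for compound 4 is therefore a step of a number 1.6 percentage points lower from compound 2 to compound 4 (within the scatter), which amounts to no change beyond the scatter. Compound 4 is estimated to give 26% in this assay, with a range from 10% to 42%.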

Compound 4, a percentage reported as activity, at one dose (the size of the read-out at that dose, not a potency): 44.7%
Estimate against measurement, compound 4: 18.7 percentage points below, outside the stated range (above it).
By their numbers in this assay, from the lowest: compounds 2, 3, 1 and 4 (each within the scatter of the next, the first and the last beyond it).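

In this assay, among the compounds shown here, the saturated chain carbon, three bonds along the chain from an amide-type nitrogen and a carbonyl carbon, emerges as a place where a single change reaches beyond the scatter: there is a number 17.1 percentage points higher from compound 2 to compound 4 (beyond the scatter), whereas the one earlier step, a number 2.8 percentage points higher from compound 2 to compound 3 (within the scatter), concerned another part of the molecule and stayed within it. For this pair, the group of 5 heavy atoms with its 3 nitrogens is therefore not required for the read-out at this dose, since carboxy in its place gives a modest gain rather than a loss. Nothing available explains this gain, so the result stands as an observation about this one pair.

From the compounds shown here alone, whether the gain depends on carboxy itself or simply on the departure of the larger group remains open, and a primary amine, a methyl ester or a carboxylic acid on a longer chain at the same place would help separate these readings. Also open, going by these compounds, is whether the gain persists at other doses and times, and whether benzyl on the terminal acid of compound 4 would again leave the read-out within the scatter.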